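From compound 2 to the benzamido compound 3

The compounds below may be only part of what the source reports. "The series", "measured", "known", "first", "only" and "open" are said of these compounds alone.

Measured in an ADME assay on Vero cells (Chlorocebus sabaeus) for cytotoxicity, read by MTT assay, with a stated time of 48 h; on this read-out lower numbers stand for stronger inhibition and higher numbers for weaker inhibition (both values are limits):
compound 1 `CS(=O)(=O)OC1CCC(CN2CCN(c3cc(=O)c4cc(C(F)(F)F)cc([N+](=O)[O-])c4s3)CC2)CC1`: > 64 ug/mL (limit)
compound 2 `CCCC(=O)OC1CCC(CN2CCN(c3cc(=O)c4cc(C(F)(F)F)cc([N+](=O)[O-])c4s3)CC2)CC1`: > 64 ug/mL (limit)

Compound 2 reads > 64 ug/mL and this is a limit, not a number. Going by the values given here, the one measured step is a step that the two limits leave unreadable from compound 1 to compound 2 and it gives no size to carry forward. The record so far is the limit of > 64 ug/mL in this assay, at which 2 of the 2 values shown sit, and it holds no numeric value.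

Compound 3 `O=C(NC1CCC(CN2CCN(c3cc(=O)c4cc(C(F)(F)F)cc([N+](=O)[O-])c4s3)CC2)CC1)c1ccccc1` carries benzamido in place of (propylcarbonyl)oxy on a saturated ring carbon, in detail benzamido in place of (propylcarbonyl)oxy on a saturated ring carbon and the rest of the structure is shared. Among the compounds with values here, no measured step shows what this change does in this assay so no direction can be read from the data. The expected step is a number no higher from compound 2 to compound 3 (the limit leaves the size open) and no move beyond the scatter is expected. This expectation rests on compound 2 at > 64 ug/mL as a limit. The estimate for compound 3 is 64 ug/mL with an expected range from 30 ug/mL to 128 ug/mL and another limit reading is likely.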

Compound 3, half-maximal inhibitory concentration: 44.3 ug/mL
Estimate against measurement, compound 3: 1.4-fold (0.16 log units) above, and the stated range covers the measured number.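

In this assay, going by these compounds alone, compound 3 gives 44.3 ug/mL, the first reading that is a number and not a limit, so a group on this saturated ring carbon can now be tied to a numeric value. Benzamido in place of (propylcarbonyl)oxy gives an at least 1.4-fold lower number from compound 2 to compound 3 (0.15 log units; that floor lies within the scatter), and benzamido in place of (methylsulfonyl)oxy gives an at least 1.4-fold lower number from compound 1 to compound 3 (0.15 log units; that floor lies within the scatter); each step has a limit at its start, so only a floor can be read and its full size stays open. Compound 1 and compound 2 share one limit and give no number: the limit of > 64 ug/mL in this assay, at which 2 of the 3 values shown sit.

Going by these compounds, it remains open whether the number for compound 3 goes with the amide link or with the six-membered aromatic ring. An acetamido group or a benzoyloxy group on the same ring carbon would separate these two parts of the change.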